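Swapping Fluoro for Trifluoromethyl on an Aromatic Carbon

This account rests on a few compounds, and the source may have more. Where it says the series, first, only, none or still open, it means among the compounds named here.

Measured in a functional assay on MCF7 cells (Homo sapiens) for antiproliferative activity, read by MTT assay, with a stated time of 72 h; a lower number here means a stronger inhibitor, a higher number a weaker inhibitor:
compound 1 `CC1=CC[C@H]2[C@H](CC[C@]2(C)O)C(C)(C)[C@@H]1CC[C@H]1[C@]2(C)CC[C@H](OC(=O)c3ccccc3)C(C)(C)O[C@H]2CC[C@@]1(C)O`: 21000 nM
compound 2 `CC1=CC[C@H]2[C@H](CC[C@]2(C)O)C(C)(C)[C@@H]1CC[C@H]1[C@]2(C)CC[C@H](OC(=O)c3ccc(F)cc3)C(C)(C)O[C@H]2CC[C@@]1(C)O`: 33500 nM

For the measured compounds named here, only two numbers exist so far, and they cannot be ranked. In this assay, compound 2 gives 33500 nM, which lies within the scatter of the only other result. Compound 3 `CC1=CC[C@H]2[C@H](CC[C@]2(C)O)C(C)(C)[C@@H]1CC[C@H]1[C@]2(C)CC[C@H](OC(=O)c3ccc(C(F)(F)F)cc3)C(C)(C)O[C@H]2CC[C@@]1(C)O` keeps the core of compound 2 and carries trifluoromethyl in place of fluoro on an aromatic carbon, para to a large group: trifluoromethyl in place of fluoro on an aromatic carbon.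

Going by the values given here, one measured step bears on this change: a 1.6-fold higher number from compound 1 to compound 2 (0.20 log units; within the scatter). That step put fluoro in place of hydrogen on an aromatic carbon, and it stayed within the scatter. Among the compounds with values here, no measured compound carries trifluoromethyl, so this evidence is thin and only indirect. With nothing pointing either way, no clear direction is expected in this assay, and no shift beyond the scatter is expected either. The estimated step is a 1.1-fold lower number from compound 2 to compound 3 (0.05 log units; within the scatter). For compound 3 the expected value is 30000 nM, with an estimated range from 14000 nM to 65000 nM.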

Compound 3, half-maximal inhibitory concentration: 23400 nM
The estimate for compound 3 lay 1.3-fold (0.11 log units) above the measured number; low and high end bracket the measured number.
By their numbers in this assay, from the lowest: compounds 1, 3 and 2 (each within the scatter of the next).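

In this assay the exchange of fluoro, a single heavy atom, for trifluoromethyl, with four heavy atoms, gives a 1.4-fold lower number from compound 2 to compound 3 (0.16 log units; within the scatter) and does not separate the two compounds. Trifluoromethyl in place of hydrogen gives a 1.1-fold higher number from compound 1 to compound 3 (0.05 log units; within the scatter) as well, so the earlier finding for a lone fluorine now extends to a larger group: on this aromatic carbon, para to a large group, hydrogen, fluoro and trifluoromethyl cannot be told apart in this assay. No independent measurement is available to explain why these three compounds read alike.

On these data alone, all three groups carry no hydrogen-bond donors or acceptors and no net charge, so it remains open whether an amine, a carboxylic acid or a hydroxyl group at this same carbon would give a number beyond the scatter. As far as these compounds go, it is also open whether a longer chain would still fit this pattern, or whether any change at this place can move the result in this assay at all while the rest of the shared core stays the same.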